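This account rests on a few compounds, and the source may have more. Where it says the series, first, only, none or still open, it means among the compounds named here.

Measured so far in a functional assay on MCF7 cells (Homo sapiens) for inhibition, read by CCK-8 assay, with a stated time of 48 h; a lower number here means a stronger inhibitor, a higher number a weaker inhibitor:

compound 1, `COc1cc(-c2cc3nccc(-c4c[nH]c5ccccc45)n3n2)cc(OC)c1OC`: > 10000 nM
compound 2, `COc1cc(-c2ccnc3cc(-c4ccccc4)nn23)cc(OC)c1OC`: 254 nM
compound 3, `COc1cc(-c2ccnc3cc(-c4ccc(C(F)(F)F)cc4)nn23)cc(OC)c1OC`: 2440 nM

Compound 1 gives only a limit in this assay, > 10000 nM, not a number; that is the limit of > 10000 nM in this assay, at which 1 of the 3 values shown sits. Among the compounds with values here, compound 2 gives 254 nM and holds the lowest of the two numbers so far. Within the data shown here, compound 3 gives 2440 nM; the step between them, a 9.6-fold higher number from compound 2 to compound 3 (0.98 log units; beyond the scatter), is the only measured change on that phenyl ring and it weakened inhibition.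

Compound 4, `COc1ccc(-c2cc3nccc(-c4cc(OC)c(OC)c(OC)c4)n3n2)cc1`, has not yet been measured. It differs from compound 2 by methoxy in place of hydrogen on an aromatic carbon. Among the measured compounds shown here, the single comparable step, trifluoromethyl in place of hydrogen on an aromatic carbon, from compound 2 to compound 3, reads as a modest loss; the methoxy is a different group, and no measured step speaks to it directly. A smaller loss than that seen for compound 3, or none beyond the scatter, is therefore expected, so that the step of a 2.0-fold higher number from compound 2 to compound 4 (0.29 log units; within the scatter) is estimated as slight. Compound 4 is expected to give about 500 nM, within a range from 150 nM to 2500 nM.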

Compound 4, half-maximal inhibitory concentration: 125 nM
Compound 4: the middle estimate sits 4.0-fold (0.60 log units) above what was measured; the measured number lies below the stated range.
By their numbers in this assay, from the lowest: compound 4; then compound 2; then compound 3. At a limit, above all of these: compound 1.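

In this assay, within the data shown here, the only earlier change on this phenyl ring had brought a loss, whereas methoxy, para to a large group, brings a gain: a 2.0-fold lower number from compound 2 to compound 4 (0.31 log units; beyond the scatter). Placing methoxy where trifluoromethyl stood gives a much wider step, a 20-fold lower number from compound 3 to compound 4 (1.29 log units; beyond the scatter), so the direction of change at this position depends on which group enters, not merely on hydrogen being replaced. Nothing shown here accounts for the difference between the two groups.

On these data alone, with only these two groups at this position, it remains open whether fluorine, an amine or a carboxylic acid would follow methoxy or trifluoromethyl, and whether a longer chain such as ethoxy would keep the gain. Also open, as far as these compounds go, is whether methoxy would give the same result elsewhere on this ring.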